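Cytotoxicity Limits in a Small Series and One Unmeasured Analogue

This account rests on a few compounds, and the source may have more. Where it says the series, first, only, none or still open, it means among the compounds named here.

Compound 1 `CCN(CC)c1nc(Cc2c(F)cccc2F)cc(=O)[nH]1`: > 85000 nM
Compound 2 `CCCN(CCC)c1nc(Cc2c(F)cccc2F)cc(=O)[nH]1`: > 78000 nM
Compound 3 `CCN(CC)c1nc(Cc2c(F)cccc2F)c(C)c(=O)[nH]1`: > 81000 nM

In an ADME assay on MT4 cells (Homo sapiens) for cytotoxicity, read by MTT assay, with a stated time of 4 days (a higher number here means that more compound is tolerated, a lower number that less compound is tolerated), compound 1 gives > 85000 nM, which is a limit of the assay and not a number. Compound 2 gives > 78000 nM in this assay, again only a limit. Compound 3 gives > 81000 nM in this assay, also a limit. The change from compound 1 to compound 2 is dipropylamino in place of diethylamino on an aromatic carbon, and the step it made is a step that the two limits leave unreadable from compound 1 to compound 2. The two cores differ by methyl in place of hydrogen on an aromatic carbon, with the step that the two limits leave unreadable from compound 1 to compound 3.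

Compound 4 `CCCN(CCC)c1nc(Cc2c(F)cccc2F)c(C)c(=O)[nH]1` has not been measured in this assay. It differs from compound 3 by dipropylamino in place of diethylamino on an aromatic carbon, the same kind of change as from compound 1 to compound 2, though here the place is also para to a methyl group (1 heavy atom). Since compound 1 sits at the limit of > 85000 nM in this assay, at which 1 of the 3 values shown sits, and compound 2 at the limit of > 78000 nM in this assay, at which 1 of the 3 values shown sits, the step from compound 3 to compound 4 is expected to be an at least 1.0-fold lower number from compound 3 to compound 4 (0.00 log units; that floor lies within the scatter). Compound 4 is therefore expected to reach roughly 80000 nM, most likely reported as a limit, between 40000 nM and 160000 nM.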

Compound 4, half-maximal cytotoxic concentration: > 74000 nM
Compound 4: no number, only a limit; the forecaster's own chance of this, stated with the estimate: 85%; the middle value does not contradict the limit.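

In this assay compound 4 gives > 74000 nM, which is again only a limit of the assay and not a number. The steps from compound 3 and from compound 2 to compound 4 cannot be read. The compounds shown leave open at what concentration any of the four becomes cytotoxic, and whether dipropylamino in place of diethylamino or methyl in place of hydrogen alters that concentration.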